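The compounds below may be only part of what the source reports. "The series", "measured", "known", "first", "only" and "open" are said of these compounds alone.

Compound 1 `O=C(Nc1cccc(-c2oc3cc(-c4ccc(F)cc4)ccc3c(=O)c2O)c1)c1ccc(F)cc1` gives 6930 nM in a functional assay on A549 cells (Homo sapiens) for antiproliferative activity, read by CCK-8 assay, with a stated time of 72 h; on this read-out higher numbers stand for weaker inhibition and lower numbers for stronger inhibition. Within the data shown here, compound 2 `O=C(Nc1cccc(-c2oc3cc(-c4ccc(F)cc4)ccc3c(=O)c2O)c1)c1ccc(Cl)cc1` gives 10800 nM in this assay; the step is a 1.6-fold higher number from compound 1 to compound 2 (0.19 log units; within the scatter), so compound 2 and compound 1 lie within the scatter of each other, and compound 1 is the only neighbour of compound 2 among the numbers so far. Compound 3 `O=C(Nc1cccc(-c2oc3cc(-c4ccc(F)cc4)ccc3c(=O)c2O)c1)c1ccc(F)cc1F` carries 2,4-difluorophenyl in place of 4-chlorophenyl on a carbonyl carbon. Among the measured compounds shown here, only the step from compound 1 to compound 2, a halide swap on the same aromatic ring, bears on this, and it stayed within the scatter, so in this assay a step of a 1.3-fold lower number from compound 2 to compound 3 (0.10 log units; within the scatter) is expected, with no direction beyond the scatter. Compound 3 is therefore estimated at 8500 nM, within 3500 nM to 21000 nM.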

Compound 3, half-maximal inhibitory concentration: 20500 nM
The estimate for compound 3 lay 2.4-fold (0.38 log units) below the measured number; measured number inside the range.
By their numbers in this assay, from the lowest: compounds 1, 2 and 3 (each within the scatter of the next, the first and the last beyond it).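

In this assay, among these compounds, adding fluoro in place of hydrogen on an aromatic carbon gives a 3.0-fold higher number from compound 1 to compound 3 (0.47 log units; beyond the scatter), a modest loss and the first step beyond the scatter at this aromatic ring. Replacing 4-chlorophenyl with 2,4-difluorophenyl gives a 1.9-fold higher number from compound 2 to compound 3 (0.28 log units; within the scatter) and does not separate those two compounds. No evidence here bears on the reason for the modest loss.

The compounds shown leave open whether the fluoro effect depends on where it sits on the ring. They also leave open how a methoxy group or an amine on this ring would fare.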